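Ethoxy to methylamino on the carbonyl carbon

This account rests on a few compounds, and the source may have more. Where it says the series, first, only, none or still open, it means among the compounds named here.

Compound 1 `CC(=O)C1(c2cc(F)cc(OCc3ccc(-n4ccnc4C)cc3)c2)CCOCC1` gives 12 mg/kg
Compound 2 `COC1(c2cc(F)cc(OCc3ccc(-n4ccnc4C)cc3)c2)CCOCC1` gives 2 mg/kg
Compound 3 `CCOC(=O)C1(c2cc(F)cc(OCc3ccc(-n4ccnc4C)cc3)c2)CCOCC1` gives 16 mg/kg

In a functional assay on the whole organism for activation, with Mus musculus as the target (a lower number here means that less compound is needed, a higher number that more compound is needed for the effect), compound 3 stands at 16 mg/kg and lies within the scatter of compound 1, while compound 2 is clearly apart (an 8.0-fold higher number from compound 2 to compound 3 (0.90 log units; beyond the scatter)). Compound 4 `CNC(=O)C1(c2cc(F)cc(OCc3ccc(-n4ccnc4C)cc3)c2)CCOCC1` has methylamino in place of ethoxy on a carbonyl carbon. The closest measured change also keeps the carbonyl and alters only its other group (a 1.3-fold higher number from compound 1 to compound 3 (0.12 log units; within the scatter)). The change to methoxy removes the carbonyl group altogether (a 6.0-fold lower number from compound 1 to compound 2 (0.78 log units; beyond the scatter)) and so bears less on this step. Going by the values given here, no measured compound carries methylamino, so the expectation is uncertain. No step beyond the scatter is expected in this assay, and the estimated step is small (a 1.3-fold lower number from compound 3 to compound 4 (0.12 log units; within the scatter)). The estimate for compound 4 is 12 mg/kg (range 4 mg/kg to 35 mg/kg).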

Compound 4, dose for half-maximal effect: 13 mg/kg
The estimate for compound 4 lay 1.1-fold (0.03 log units) below the measured number, and the stated range covers the measured number.
By their numbers in this assay, from the lowest: compound 2; then compounds 1, 4 and 3 (each within the scatter of the next).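

In this assay the new amide does not separate from the ester (a 1.2-fold lower number from compound 3 to compound 4 (0.09 log units; within the scatter)) or from the ketone (a 1.1-fold higher number from compound 1 to compound 4 (0.03 log units; within the scatter)), so exchanging the group on the carbonyl carbon has shown no effect beyond the scatter in these three compounds. Compound 2, which has methoxy on the saturated ring carbon, stays apart from the amide as well (a 6.5-fold higher number from compound 2 to compound 4 (0.81 log units; beyond the scatter)). No evidence available here explains either result.

As far as these compounds go, whether a carboxylic acid or a longer chain on the carbonyl carbon would stay with this group remains open. So does whether a hydroxyl group on the saturated ring carbon would match compound 2.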